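Dropping one chloro from the dichlorophenyl amide

The source may report more compounds than this note shows. Statements on the series, on what has been measured and on what is new or still open speak of the compounds shown alone.

Of the compounds shown here, three sharing one core have been measured in an assay on isolated protein for displacement of a labelled ligand from melanin-concentrating hormone receptor 1 (Homo sapiens); a lower number here means a stronger inhibitor, a higher number a weaker inhibitor. Compound 1 `CCCc1ccc(/C=C/C(=O)Nc2ccc3nc(CCC)cc(N)c3c2)cc1` gives 4 nM in this assay, compound 2 `CCCc1cc(N)c2cc(NC(=O)/C=C/c3ccc(I)cc3)ccc2n1` gives 2.3 nM, and compound 3 `CCCc1cc(N)c2cc(NC(=O)/C=C/c3ccc(Cl)c(Cl)c3)ccc2n1` gives 60 nM. Compound 3 thus has the highest number of the three: the step of a 15-fold higher number from compound 1 to compound 3 (1.18 log units; beyond the scatter) and the step of a 26-fold higher number from compound 2 to compound 3 (1.42 log units; beyond the scatter) are both large and beyond the scatter, whereas the step of a 1.7-fold lower number from compound 1 to compound 2 (0.24 log units; within the scatter) is within it.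

Compound 4 `CCCc1cc(N)c2cc(NC(=O)/C=C/c3ccc(Cl)cc3)ccc2n1` differs from compound 3 in one place: hydrogen in place of chloro on an aromatic carbon, so the 3,4-dichlorophenyl becomes a 4-chlorophenyl. The two large steps bear on this change, since both of them swapped a 4-substituted phenyl for the 3,4-dichlorophenyl, and both raised the number. For the measured compounds named here, compound 4 carries a single 4-substituent again, so the number is expected to fall back, as a 7.5-fold lower number from compound 3 to compound 4 (0.88 log units; beyond the scatter), though no measured step shows exactly this change. For compound 4 the estimate in this assay is 8 nM, within a range from 3 nM to 25 nM.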

Compound 4, half-maximal inhibitory concentration: 6 nM
Compound 4: the middle estimate sits 1.3-fold (0.12 log units) above what was measured; measured number inside the range.
By their numbers in this assay, from the lowest: compounds 2, 1 and 4 (each within the scatter of the next, the first and the last beyond it); then compound 3.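

Taking away only the chloro that sits ortho to a chloro group and meta to a large group gives a 10-fold lower number from compound 3 to compound 4 (1.00 log units; beyond the scatter) in this assay. The earlier steps shown here replaced a whole substituted phenyl, whereas this one ties the high number of compound 3 to that single chloro. Once it is gone, the group left on the phenyl counts for less: chloro in place of propyl gives a step within the scatter (a 1.5-fold higher number from compound 1 to compound 4 (0.18 log units; within the scatter)), and chloro in place of iodo gives a modest step beyond it (a 2.6-fold higher number from compound 2 to compound 4 (0.42 log units; beyond the scatter)).

No measurement here explains why this one chloro has so large an effect. On these data alone, it also remains open whether a fluoro or a methoxy group in its place would leave the number near that of compound 4 or raise it towards that of compound 3.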